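From urea to cyclopropyl amide on a shared core

This account rests on a few compounds, and the source may have more. Where it says the series, first, only, none or still open, it means among the compounds named here.

Compound 3 `CCNC(=O)NCCCc1cccc2c1C[C@@H](CCCCc1ccccc1)O2` gives 40 nM in an assay on NIH3T3 cells for binding affinity to melatonin receptor type 1B (Homo sapiens) (a higher number here means a weaker inhibitor, a lower number a stronger inhibitor), level with compound 1 `CC(C)C(=O)NCCCc1cccc2c1C[C@@H](CCCCc1ccccc1)O2` at 40 nM, and together these are the highest of the three numbers measured. Compound 2 `CCC(=O)NC[C@@H]1C[C@H]1c1cccc2c1C[C@@H](CCCCc1ccccc1)O2` gives 2 nM. The gap to the weaker pair is a 20-fold higher number from compound 2 to compound 3 (1.30 log units; beyond the scatter). Compound 4 `O=C(NCCCc1cccc2c1C[C@@H](CCCCc1ccccc1)O2)C1CC1` differs from compound 3 by cyclopropyl in place of ethylamino on a carbonyl carbon. Within the data shown here, the only measured step that touches this place is no change at the digits printed from compound 1 to compound 3 (within the scatter), a swap on the same carbonyl carbon that left the number unchanged. Compound 4 is therefore expected to sit close to compound 3, with no change at the digits printed from compound 3 to compound 4 (within the scatter). Compound 4 is estimated at 40 nM, within a range from 15 nM to 110 nM.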

Compound 4, inhibition constant: 30 nM
For compound 4 the middle estimate is 1.3-fold (0.12 log units) above the measured one, within the range that was stated.
By their numbers in this assay, from the lowest: compound 2; then compounds 4, 1 and 3 (each within the scatter of the next).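

Cyclopropyl on this carbonyl carbon gives a 1.3-fold lower number from compound 3 to compound 4 (0.12 log units; within the scatter) and a 1.3-fold lower number from compound 1 to compound 4 (0.12 log units; within the scatter), so in this assay a group carrying a ring reads alike with ethylamino and isopropyl. Changing the group here does not close the large gap set by the side chain, which stands at a 15-fold higher number from compound 2 to compound 4 (1.18 log units; beyond the scatter). No supporting measurement bears on why these numbers fall as they do. Still open, as far as these compounds go, is whether a phenyl ring or a longer chain on this carbonyl carbon would also read alike, and how cyclopropyl would read in place of ethyl on the carbonyl of compound 2.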